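The source may report more compounds than this note shows. Statements on the series, on what has been measured and on what is new or still open speak of the compounds shown alone.

Measured in a functional assay, read by fluorescence and spectrophotometry, with a stated time of 1 h; a higher number here means that more compound is needed for the effect, a lower number that less compound is needed:
- compound 1 `C=CCCCCCCS(=O)(=O)/C=C/c1ccc(O)c(O)c1`: 6400 nM
- compound 2 `O=S(=O)(/C=C/c1ccc(O)c(O)c1)CCC1CCCCC1`: 9800 nM
- compound 3 `CCCCCCCCCCS(=O)(=O)/C=C/c1ccc(O)c(O)c1`: 6800 nM

All three compounds share one core and differ only in the group carried on the sulfonyl sulfur. Compound 3, at 6800 nM, lies within the usual scatter of both compound 1 and compound 2, so these numbers set no meaningful order among the three.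

The next compound is compound 4 `O=S(=O)(/C=C/c1ccc(O)c(O)c1)CCCC1CCCCC1`, which has not yet been measured. Starting from compound 3, the change is cyclohexyl in place of heptyl on a saturated chain carbon, three bonds along the chain from a sulfonyl sulfur. An open chain end thus gives way to a ring.

Within the data shown here, two measured steps bear on this. The closest is the one that brought in a cyclohexyl group, two bonds along the chain rather than three, a 1.5-fold higher number from compound 1 to compound 2 (0.19 log units; within the scatter). The other altered only the open chain, a 1.1-fold higher number from compound 1 to compound 3 (0.03 log units; within the scatter). Going by these compounds, both steps stayed within the scatter, so in this assay no step beyond the scatter is expected here, and the direction remains open. Three compounds are a thin basis, so the range is kept wide.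

The estimated step is a 1.1-fold higher number from compound 3 to compound 4 (0.04 log units; within the scatter). For compound 4 the expected value is 7500 nM, with an estimated range from 4000 nM to 14000 nM.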

Compound 4, half-maximal effective concentration: 7900 nM
Compound 4: middle estimate off by 1.1-fold (0.02 log units), on the low side; low and high end bracket the measured number.
By their numbers in this assay, from the lowest: compounds 1, 3, 4 and 2 (each within the scatter of the next).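

In this assay, the open end of the chain gives way to a ring, with cyclohexyl in place of heptyl on a saturated chain carbon, three bonds along the chain from a sulfonyl sulfur, and the result is a 1.2-fold higher number from compound 3 to compound 4 (0.07 log units; within the scatter). The same compound can be read against two others: cyclohexylmethyl in place of cyclohexyl, two bonds along the chain from a sulfonyl sulfur, gives a 1.2-fold lower number from compound 2 to compound 4 (0.09 log units; within the scatter), and cyclohexyl in place of pent-4-en-1-yl, three bonds along the chain, gives a 1.2-fold higher number from compound 1 to compound 4 (0.09 log units; within the scatter). This assay therefore does not separate an open chain from a chain ending in a six-membered ring, nor the two ring placements from each other, and no supporting measurement speaks to why.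

Every group shown on the sulfonyl sulfur is built of carbon alone, so it remains open whether a chain ending in an amine or a carboxylic acid would step beyond the scatter. The same question stands for a phenyl ring in place of cyclohexyl and for a much shorter chain such as ethyl.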